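The source may report more compounds than this note shows. Statements on the series, on what has been measured and on what is new or still open speak of the compounds shown alone.

Measured in a functional assay on NCI-N87 cells (Homo sapiens) for inhibition, read by CellTiter-Glo, with a stated time of 72 h; a lower number here means a stronger inhibitor, a higher number a weaker inhibitor:
- compound 1 `Cc1cc(Nc2ncnc3cc(O)c(NC(=O)/C=C/[C@H]4CCCN4C)cc23)ccc1Oc1cnc2ccnn2c1`: 1.9 nM
- compound 2 `Cc1cc(Nc2ncnc3cc(O)c(NC(=O)/C=C/[C@H]4CCCN4C)cc23)ccc1Oc1cc2nccn2cn1`: 41.7 nM

Compound 2 holds the higher of the two numbers, making it the weaker inhibitor of the pair. Compound 3 `Cc1cc(Nc2ncnc3cc(O)c(NC(=O)/C=C/[C@H]4CCCN4C)cc23)ccc1Oc1ccn2ccnc2c1` differs from compound 2 by a group of 9 heavy atoms (7 carbon, 2 nitrogen; one five-membered aromatic ring with 2 hetero atoms, one six-membered aromatic ring with 1 hetero atom) in place of a group of 9 heavy atoms (6 carbon, 3 nitrogen; one five-membered aromatic ring with 2 hetero atoms, one six-membered aromatic ring with 2 hetero atoms), on an oxygen on an aromatic ring. Within the data shown here, one measured step bears on this change: a 22-fold higher number from compound 1 to compound 2 (1.34 log units; beyond the scatter), a large step that also exchanges one such group for another on that oxygen. A similar exchange could therefore move the number well beyond the scatter, and a moderate drop in this assay is expected, though the direction is uncertain. The expected change is a 4.6-fold lower number from compound 2 to compound 3 (0.67 log units; beyond the scatter). For compound 3 the estimated value is 9 nM, with an expected range from 2 nM to 40 nM.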

Compound 3, half-maximal inhibitory concentration: 4.55 nM
For compound 3 the middle estimate is 2.0-fold (0.30 log units) above the measured one; the measured number falls inside the stated range.
By their numbers in this assay, from the lowest: compound 1; then compound 3; then compound 2.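

In this assay, a change of group on this oxygen can also lower the number: a 9.2-fold lower number from compound 2 to compound 3 (0.96 log units; beyond the scatter) shows this for the group with one six-membered aromatic ring with 1 hetero atom. The remaining gap, a 2.4-fold higher number from compound 1 to compound 3 (0.38 log units; beyond the scatter), is modest but beyond the scatter, so all three groups are told apart at this position, with compound 1 holding the lowest number. Nothing available explains these differences.

The compounds shown leave open how a single ring, such as phenyl or pyridine, would fare on this oxygen.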